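The source may hold more compounds than are shown below. What is called first, only, known or untested is meant among the compounds shown, and "the series" means these compounds.

Measured compounds in an assay on microsomes from brain for inhibition of Fatty-acid amide hydrolase 1 (Rattus norvegicus), read by fluorescence and HPLC, with a stated time of 60 min; a higher number here means a weaker inhibitor, a lower number a stronger inhibitor:
Compound 1, `CCCCCCCCc1ccc(OCC(=O)Cn2nnc(-c3ccc(Cl)cc3)n2)cc1`, gives 35 nM.
Compound 2, `CCCCCCCCc1ccc(OCC(=O)Cn2nnc(-c3cccc(Cl)c3)n2)cc1`, gives 24 nM.
Compound 3, `CCCCCCCCc1ccc(OCC(=O)Cn2nnc(C(=O)O)n2)cc1`, gives 41 nM.

Among these three numbers compound 1 stands second highest. Its two steps to the others are small: a 1.2-fold higher number from compound 1 to compound 3 (0.07 log units; within the scatter) and a 1.5-fold lower number from compound 1 to compound 2 (0.16 log units; within the scatter), both within the scatter, so the three compounds cannot be ranked against each other on this assay.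

Compound 4, `CCCCCCCCc1ccc(OC(C)C(=O)Cn2nnc(-c3ccc(Cl)cc3)n2)cc1`, is the next compound to be measured in this assay. It differs from compound 1 by methyl in place of hydrogen on a saturated chain carbon bound to a carbonyl carbon and an oxygen on an aromatic ring. The shared core is otherwise untouched.

For the measured compounds named here, none of the measured steps touches this place. The steps of a 1.5-fold lower number from compound 1 to compound 2 (0.16 log units; within the scatter), a 1.2-fold higher number from compound 1 to compound 3 (0.07 log units; within the scatter) and a 1.7-fold higher number from compound 2 to compound 3 (0.23 log units; within the scatter) all alter the group on the aromatic carbon of the shared core, far from the saturated chain carbon where the methyl enters, and all three stay within the scatter. Going by the values given here, the measured compounds therefore give no direct guide to the change in compound 4; what they do show is that the series so far tolerates variation without a step beyond the scatter.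

On that basis the estimate for compound 4 in this assay is 40 nM, with a range from 15 nM to 110 nM, which is expected to mean a 1.1-fold higher number from compound 1 to compound 4 (0.06 log units; within the scatter), no step beyond the scatter.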

Compound 4, half-maximal inhibitory concentration: 35 nM
Beside the measured number, compound 4's estimate is 1.1-fold (0.06 log units) above it, within the range that was stated.
By their numbers in this assay, from the lowest: compounds 2, 1, 4 and 3 (each within the scatter of the next).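

In this assay the methyl in place of hydrogen on a saturated chain carbon bound to a carbonyl carbon and an oxygen on an aromatic ring gives no change at the digits printed from compound 1 to compound 4 (within the scatter), and this is the first step shown at this place rather than on the aromatic carbon of the shared core. It shows that this chain carbon, like that aromatic carbon, can carry a change without a step beyond the scatter, although the evidence here is a single pair, with 4-chlorophenyl held constant on the shared core. No measurement shown offers any explanation for this result.

The compounds shown leave open whether the same chain carbon would accept an ethyl group, a phenyl ring, a hydroxyl group or an amine as readily as it accepts the methyl. They also leave open whether the methyl would give a similar result with the 3-chlorophenyl of compound 2 or the carboxy group of compound 3 in place of the 4-chlorophenyl.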